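The source may report more compounds than this note shows. Statements on the series, on what has been measured and on what is new or still open speak of the compounds shown alone.

Series notes. Compound 1 `CCCS(=O)(=O)Nc1ccc(F)c(C(=O)c2n[nH]c3ncc(-c4ccccc4F)cc23)c1F` in an assay for binding affinity to dual specificity mitogen-activated protein kinase kinase 4 (Homo sapiens), read by KINOMEscan, tested at 100 nM (a higher number here means a weaker effect of the compound at the concentration tested, a lower number a stronger effect), gives 2%. Compound 2 `CCCS(=O)(=O)Nc1ccc(F)c(C(=O)c2n[nH]c3ncc(-c4ccc(S(N)(=O)=O)cc4)cc23)c1F` gives 0.25% in this assay, and compound 3 `CCCS(=O)(=O)Nc1ccc(F)c(C(=O)c2n[nH]c3ncc(-c4ccc(S(=O)(=O)NC)cc4)cc23)c1F` gives 1.2% in this assay. All three sit close together: a number 1.8 percentage points lower from compound 1 to compound 2 (within the scatter), a number 0.8 percentage points lower from compound 1 to compound 3 (within the scatter) and a number 1 percentage points higher from compound 2 to compound 3 (within the scatter), each within the scatter. Compound 3 thus stands second highest of the three numbers, nearest compound 1 and furthest from compound 2, with neither gap beyond the scatter.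

Compound 4 `CCCS(=O)(=O)Nc1ccc(F)c(C(=O)c2n[nH]c3ncc(-c4ccc(S(=O)(=O)NCC)cc4)cc23)c1F` is not yet measured in this assay. It differs from compound 3 by methyl in place of hydrogen on a saturated chain carbon bound to a sulfonamide nitrogen. Within the data shown here, the one measured step that bears on this is the earlier growth on the sulfonamide nitrogen, a number 1 percentage points higher from compound 2 to compound 3 (within the scatter), which stayed within the scatter; the change to compound 4 reads methylsulfamoyl to ethylsulfamoyl on the same group. No step beyond the scatter is therefore expected in this assay. The step of a number 0.3 percentage points higher from compound 3 to compound 4 (within the scatter) is expected to stay within the scatter. For compound 4 the estimate in this assay is 1.5%, with a range from 0.2% to 8%.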

Compound 4, a percentage reported as activity, at one concentration (the size of the read-out at that concentration, not a potency): 3%
The estimate for compound 4 lay 1.5 percentage points below the measured number; the measured number falls inside the stated range.
By their numbers in this assay, from the lowest: compounds 2, 3, 1 and 4 (each within the scatter of the next).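

Ethyl is carried on the sulfonamide nitrogen in this assay without a step beyond the scatter: methylsulfamoyl to ethylsulfamoyl gives a number 1.8 percentage points higher from compound 3 to compound 4 (within the scatter) and stays within it. The same holds for the whole growth from the unsubstituted sulfonamide, with a number 2.8 percentage points higher from compound 2 to compound 4 (within the scatter) on record, and for the exchange of the aryl group on the shared core, with a number 1 percentage points higher from compound 1 to compound 4 (within the scatter) on record, so all of these changes leave the read-out unresolved at this concentration. No measurement at hand accounts for these numbers.

As far as these compounds go, whether a longer chain such as propyl or butyl on the sulfonamide nitrogen, a second methyl on that nitrogen, or a carboxylic acid in place of the sulfonamide would produce a step beyond the scatter remains open. The read-out at one concentration also gives no potency for any of the four compounds.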